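Phenyl for allyl on a series at the assay limit

This account rests on a few compounds, and the source may have more. Where it says the series, first, only, none or still open, it means among the compounds named here.

Measured in a functional assay on BV-2 cells (Mus musculus) for inhibition, read by Griess assay, with a stated time of 24 h; a higher number here means a weaker inhibitor, a lower number a stronger inhibitor:
- compound 1 `COc1ccc(Br)cc1-c1ccn(-c2ccccc2)n1` gives > 200000 nM (a limit)
- compound 2 `C=CCc1ccc(OC)c(-c2ccn(CC=C)n2)c1` gives > 200000 nM (a limit)

Compound 2 has no numerical value, only a limit. Among the compounds with values here, the record so far is the limit of > 200000 nM in this assay, at which 2 of the 2 values shown sit (no numerical reading exists), and no step between measured compounds can be stated.

Within the data shown here, compound 3 `C=CCc1ccc(OC)c(-c2ccn(-c3ccccc3)n2)c1` keeps the allyl group of compound 2 elsewhere on the core but carries phenyl in place of allyl on an aromatic nitrogen (the only change).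

In this assay a small move towards stronger inhibition is expected, and possibly none that can be resolved. Compound 1 also carries phenyl on an aromatic nitrogen and reads > 200000 nM (a limit), which argues against expecting a large step. A further reading reported only as a limit would be no surprise.

The expected step is an at least 1.6-fold lower number from compound 2 to compound 3 (0.22 log units; that floor lies within the scatter) (an estimate resting on limits alone). For compound 3 the estimated value is 120000 nM (expected range 25000 nM to 300000 nM).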

Compound 3, half-maximal inhibitory concentration: 8920 nM
Compound 3: the middle estimate sits 13-fold (1.13 log units) above what was measured; the whole stated range lies above it.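

Within the data shown here, compound 3 gives the first numerical reading of the series in this assay, and phenyl in place of allyl on an aromatic nitrogen accounts for an at least 22-fold lower number from compound 2 to compound 3 (1.35 log units; beyond the scatter) on the shared core. Phenyl at this position does not bring a reading by itself: compound 1 carries the same phenyl, and allyl in place of bromo on an aromatic carbon gives an at least 22-fold lower number from compound 1 to compound 3 (1.35 log units; beyond the scatter) in this comparison. Among these three compounds, a numerical reading appears only where phenyl on the aromatic nitrogen and allyl on the aromatic carbon occur together, and both steps are open-ended, with their true sizes unknown, since each starts from a limit: the limit of > 200000 nM in this assay, at which 2 of the 3 values shown sit.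

Going by these compounds, whether the phenyl itself matters or any larger ring on this nitrogen would serve equally stays open, as a benzyl group or a longer chain there would be needed to tell these apart. On these data alone, it is equally open how much change the allyl position tolerates, for instance a propyl group or an amine in its place, and whether a reading stronger than that of compound 3 lies within reach.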